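Does Swapping the Chlorophenyl Group Change Macrophage Toxicity?

This account rests on a few compounds, and the source may have more. Where it says the series, first, only, none or still open, it means among the compounds named here.

Compound 1 `COc1cc(O)cc(O)c1C(=O)/C=C/c1ccc(Cl)cc1` gives 19000 nM
Compound 2 `COc1ccc(/C=C/C(=O)c2c(O)cc(O)cc2OC)cc1` gives 166000 nM
Compound 3 `COc1cc(O)cc(O)c1C(=O)/C=C/c1ccc(C(F)(F)F)cc1` gives 17100 nM

These three values come from a toxicity assay on cells (Macrophage, Mus musculus, strain BALB/c) for cytotoxicity, read by MTT assay (on this read-out higher numbers stand for weaker inhibition and lower numbers for stronger inhibition), and allow a first comparison. Compound 1 stands level with compound 3 and well under compound 2, so it sits at the low end of this small set, in a tie with compound 3.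

Compound 4 `COc1cc(O)cc(O)c1C(=O)/C=C/c1ccccc1F` has not been measured yet. It puts 2-fluorophenyl in place of 4-chlorophenyl (2-fluorophenyl in place of 4-chlorophenyl on a double-bonded chain carbon bound to a double-bonded chain carbon) on a double-bonded chain carbon bound to a double-bonded chain carbon, while the rest of the core of compound 1 stays the same.

Among the compounds with values here, two measured steps bear on this change, and both are exchanges on an aromatic carbon. Trifluoromethyl in place of chloro made no difference beyond the scatter (a 1.1-fold lower number from compound 1 to compound 3 (0.05 log units; within the scatter)). Methoxy in place of chloro gave a modest rise (an 8.7-fold higher number from compound 1 to compound 2 (0.94 log units; beyond the scatter)). Neither step brings in 2-fluorophenyl, so both are only a loose guide. In this assay a step within the scatter is therefore expected, leaning towards a higher number. The expected step (a 1.6-fold higher number from compound 1 to compound 4 (0.20 log units; within the scatter)) is small. For compound 4 the expected value is 30000 nM within a range from 11000 nM up to 90000 nM as estimated here.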

Compound 4, half-maximal inhibitory concentration: 16000 nM
The estimate for compound 4 lay 1.9-fold (0.27 log units) above the measured number; the range from low to high includes it.
By their numbers in this assay, from the lowest: compounds 4, 3 and 1 (each within the scatter of the next); then compound 2.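

In this assay, putting 2-fluorophenyl in place of 4-chlorophenyl gives a 1.2-fold lower number from compound 1 to compound 4 (0.07 log units; within the scatter), so the number stays level even though this step changes more than the earlier ones did. Within the data shown here, the earlier steps exchanged only a single group on an aromatic carbon, whereas here the whole 4-chlorophenyl group on the double-bonded chain carbon gives way to one with a different halogen and a different printed position, and the result still lies within the scatter. So compound 1 now has two neighbours that match it, compound 3 and compound 4, while compound 2, with its methoxy group, remains the one exception, and nothing measured here explains why these compounds match or why compound 2 differs.

The compounds shown leave open how a phenyl ring with no added group at all would compare with compound 1. They also leave open whether an amine or a carboxylic acid on the ring would keep the number level with compound 1 or shift it, as the methoxy group did in compound 2.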